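The source may report more compounds than this note shows. Statements on the series, on what has been measured and on what is new or still open speak of the compounds shown alone.

Three compounds share one core and differ only in the group on a saturated chain carbon bound to an aromatic carbon and a saturated chain carbon. In an ADME assay on microsomes from liver (Rattus norvegicus) for metabolic stability (on this read-out higher numbers stand for a longer-lived compound and lower numbers for a shorter-lived compound), compound 1 `CC(C)C(Nc1nnc[nH]1)c1ccc(-c2ccc3cccc(F)c3c2)[nH]c1=O` gives 1.29 h. Compound 2 `CC(C)C(c1ncc[nH]1)c1ccc(-c2ccc3cccc(F)c3c2)[nH]c1=O` gives < 0.0667 h, which is a limit of the assay and not a number. Compound 3 `CC(C)C(Cc1nnn[nH]1)c1ccc(-c2ccc3cccc(F)c3c2)[nH]c1=O` gives 2.08 h, which puts it level with compound 1 within the scatter and far from compound 2.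

Compound 4 `CC(C)C(/C=C1\CCNC1=O)c1ccc(-c2ccc3cccc(F)c3c2)[nH]c1=O` has not yet been measured in this assay. Its structure departs from compound 3 in one place: a group of 7 heavy atoms (5 carbon, 1 nitrogen, 1 oxygen; one five-membered non-aromatic ring with 1 hetero atom) in place of a group of 6 heavy atoms (2 carbon, 4 nitrogen; one five-membered aromatic ring with 4 hetero atoms), on a saturated chain carbon bound to an aromatic carbon and a saturated chain carbon. Within the data shown here, no measured step makes this exact swap, so the evidence is indirect. Of the three measured swaps at this place, one stayed within the scatter, a 1.6-fold higher number from compound 1 to compound 3 (0.21 log units; within the scatter), and two were large, an at least 19-fold lower number from compound 1 to compound 2 (1.28 log units; beyond the scatter) and an at least 31-fold higher number from compound 2 to compound 3 (1.49 log units; beyond the scatter). A swap here can therefore do little or a great deal. The group entering compound 4 has a non-aromatic ring, unlike the ring it replaces, so a moderate fall is the cautious expectation, short of the extreme seen in the large steps. The expected change is a 3.5-fold lower number from compound 3 to compound 4 (0.54 log units; beyond the scatter). For compound 4 the estimated half-life is 0.6 h, with an expected range from 0.12 h to 2 h.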

Compound 4, half-life: 0.345 h
Compound 4: middle estimate off by 1.7-fold (0.24 log units), on the high side, within the range that was stated.
By their numbers in this assay, from the lowest: compound 4; then compounds 1 and 3 (each within the scatter of the next). At a limit, below all of these: compound 2.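

In this assay, the group with a five-membered non-aromatic ring gives the first intermediate result at this place on the saturated chain carbon, with modest drops beyond the scatter: a 6.0-fold lower number from compound 3 to compound 4 (0.78 log units; beyond the scatter) and a 3.7-fold lower number from compound 1 to compound 4 (0.57 log units; beyond the scatter). Among these compounds, the earlier compounds showed only two numbers level with each other and one far lower, whereas the new result also stands clear of the low end, with an at least 5.1-fold higher number from compound 2 to compound 4 (0.71 log units; beyond the scatter), so an aromatic ring in the group does not by itself decide the outcome: compound 2 carries one and still ends lowest, although compound 1 and compound 3 also carry one and end highest. The size of that last step is only a bound, because compound 2 gives a limit of the assay and not a number: the limit of < 0.0667 h in this assay, at which 1 of the 4 values shown sits.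

The compounds shown leave open which feature of the entering group sets its number, since its non-aromatic ring, its double bonds and its carbonyl all arrive together. They also do not tell how an open-chain amide or a carboxylic acid at this place would behave in this assay.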